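Two dithiocarbamate chromones and a dropped methoxy

The compounds below may be only part of what the source reports. "The series", "measured", "known", "first", "only" and "open" are said of these compounds alone.

Compound 1 `COc1ccc2oc(CSC(=S)N(C(C)C)C(C)C)cc(=O)c2c1` and compound 2 `COc1ccc2occ(CSC(=S)N3CCOCC3)c(=O)c2c1` share a methoxy group on their aromatic ring but carry it on cores that differ; the difference between the two cores is not broken down here. Both were tested in a functional assay on SW480 cells (Homo sapiens) for antiproliferative activity, read by MTT assay, with a stated time of 72 h; on this read-out lower numbers stand for stronger inhibition and higher numbers for weaker inhibition. In this assay compound 1 gives 7200 nM, and compound 2 gives 7100 nM; these two values lie within the usual scatter of each other. Compound 3 `CC(C)N(C(=S)SCc1cc(=O)c2ccccc2o1)C(C)C` differs from compound 1 only in the change (hydrogen in place of methoxy on an aromatic carbon). Compound 3 reaches only a limit of this assay, not a number: > 40000 nM, which is the limit of > 40000 nM in this assay, at which 1 of the 3 values shown sits. The step from compound 1 to compound 3 is therefore an at least 5.5-fold higher number from compound 1 to compound 3 (0.74 log units; beyond the scatter).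

Compound 4 `O=c1c(CSC(=S)N2CCOCC2)coc2ccccc12` has not yet been measured. It differs from compound 2 by hydrogen in place of methoxy on an aromatic carbon, which is the same change that separates compound 1 from compound 3, at the same place on the ring. The expected step in this assay, set beside the measured step of an at least 5.5-fold higher number from compound 1 to compound 3 (0.74 log units; beyond the scatter), is a 5.6-fold higher number from compound 2 to compound 4 (0.75 log units; beyond the scatter). Compound 4 is accordingly estimated at 40000 nM in this assay, with an expected range from 15000 nM to 100000 nM, and a substantial chance that this assay again reports only a limit rather than a number.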

Compound 4, half-maximal inhibitory concentration: 5900 nM
Beside the measured number, compound 4's estimate is 6.8-fold (0.83 log units) above it, outside the stated range (below it).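

In this assay, putting hydrogen in place of methoxy on the core of compound 2 gives a 1.2-fold lower number from compound 2 to compound 4 (0.08 log units; within the scatter), so on this core the change makes no difference that can be told from the scatter. The methoxy group therefore cannot be treated as a piece with a fixed effect that carries from one core to the next, as the two steps in this series disagree: the same change on two cores in this assay, an at least 5.5-fold higher number (0.74 log units; beyond the scatter) from compound 1 to compound 3 and a 1.2-fold lower number (0.08 log units; within the scatter) from compound 2 to compound 4, at least 6.6-fold (0.82 log units) apart, beyond the scatter of two such steps What this does not show is which structural feature sets the two pairs apart, for compounds 1 and 3 differ from compounds 2 and 4 in more than one place, so two pairs can reveal the disagreement but cannot trace it to a single feature.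

From the compounds shown here alone, compound 3 gives > 40000 nM, which is a limit and not a number, so the full size of the step on its core remains open. Also open, going by these compounds, is how a longer ether such as ethoxy, or a chlorine atom, would behave in place of methoxy on either core, and whether the dithiocarbamate of compound 1 would respond as it does here if it were placed on the core of compound 2.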